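The source may report more compounds than this note shows. Statements on the series, on what has been measured and on what is new or still open speak of the compounds shown alone.

Measured compounds:
compound 1 `c1ccc2c(c1)CN[C@@H](CN(CCCCNCC1CCSCC1)[C@H]1CCCc3cccnc31)C2` — > 30000 nM
compound 2 `c1ccc2c(c1)CN[C@@H](CN(CCCCNC1CCCCC1)[C@H]1CCCc3cccnc31)C2` — > 30000 nM
compound 3 `c1ccc2c(c1)CN[C@@H](CN(CCCCNC1CCNCC1)[C@H]1CCCc3cccnc31)C2` — > 30000 nM

All three measured values in a functional assay on cells for agonist activity at C-X-C chemokine receptor type 4 (Homo sapiens), read by fluorescence and calcium flux, with a stated time of 90 s (on this read-out higher numbers stand for an effect only at larger amounts of compound and lower numbers for an effect already at smaller amounts), are limits of the assay, not numbers. Compound 1 sits at its limit, > 30000 nM. Compound 2 likewise gives only a limit, > 30000 nM. Compound 3 also stands at the limit, > 30000 nM, so its position relative to the others cannot be read. Within the data shown here, the steps among them, a step that the two limits leave unreadable from compound 1 to compound 2, a step that the two limits leave unreadable from compound 1 to compound 3 and a step that the two limits leave unreadable from compound 2 to compound 3, are therefore unreadable; the only evidence is the limit of > 30000 nM in this assay, at which 3 of the 3 values shown sit.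

Compound 4 `CC(C)(CCN)CN(C[C@H]1Cc2ccccc2CN1)[C@H]1CCCc2cccnc21` differs from compound 3 by a group of 6 heavy atoms (5 carbon, 1 nitrogen; no ring) in place of a group of 10 heavy atoms (8 carbon, 2 nitrogen; one six-membered non-aromatic ring with 1 hetero atom), on a saturated chain carbon bound to an amine nitrogen.

Among the measured compounds shown here, none of the measured steps gives a readable size, and all three changes at this amine nitrogen left the compounds at the limit. The expected step of a number no higher from compound 3 to compound 4 (the limit leaves the size open) is therefore no movement beyond the scatter, with compound 4 most likely again reported only as a limit. The estimate for compound 4 in this assay is 30000 nM, ranging from 8000 nM to 100000 nM.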

Compound 4, half-maximal effective concentration: > 30000 nM
Compound 4: a limit, no number (the forecaster's own chance of this, stated with the estimate: 80%); the middle value lies on the limit itself.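

In this assay compound 4 gives only a limit, > 30000 nM. Its steps to compound 1, compound 2 and compound 3 therefore cannot be read, and the only evidence remains: the limit of > 30000 nM in this assay, at which 4 of the 4 values shown sit.

The compounds shown leave open whether any group on this amine nitrogen gives a numeric value, and how these compounds rank.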